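This account rests on a few compounds, and the source may have more. Where it says the series, first, only, none or still open, it means among the compounds named here.

In a functional assay on HCT-116 cells (Homo sapiens) for cytotoxicity, read by MTT assay, with a stated time of 2 days, tested at 10 uM (on this read-out lower numbers stand for less inhibition and higher numbers for more inhibition at the one concentration tested (going by the name of the read-out)), three related compounds have been measured. Compound 1 `CCCCNc1nc(NCc2ccco2)c2ccccc2n1` gives 94.8%, and compound 2 `CCCCNc1nc(NCc2ccco2)c2cc(F)ccc2n1` gives 87.8%, while compound 3 `CCN(CC)CCNc1nc(NCc2ccco2)c2cc(F)ccc2n1` gives 26.4%, the least inhibition of the three. Compound 2 and compound 1 differ by hydrogen in place of fluoro on an aromatic carbon, which gives a number 7 percentage points higher from compound 2 to compound 1 (within the scatter). Compound 2 and compound 3 differ by diethylamino in place of ethyl on a saturated chain carbon, two bonds along the chain from a nitrogen on an aromatic ring, which gives a number 61.4 percentage points lower from compound 2 to compound 3 (beyond the scatter).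

Compound 4 `CCN(CC)CCNc1nc(NCc2ccco2)c2ccccc2n1` has not yet been measured in this assay. It differs from compound 3 by hydrogen in place of fluoro on an aromatic carbon, the same change, at the same place, as from compound 2 to compound 1. That earlier step, a number 7 percentage points higher from compound 2 to compound 1 (within the scatter), lay within the scatter, and nothing among these compounds points to a different outcome now. The expected step is accordingly small: a number 6.6 percentage points higher from compound 3 to compound 4 (within the scatter). Compound 4 is estimated at 33%, with a likely range from 18% to 50%.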

Compound 4, a percentage reported as inhibition, at one concentration (the size of the read-out at that concentration, not a potency): 50.3%
Beside the measured number, compound 4's estimate is 17.3 percentage points below it, outside the stated range (above it).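

In this assay, hydrogen in place of fluoro gives a number 23.9 percentage points higher from compound 3 to compound 4 (beyond the scatter), so this change does not carry over at the same size from one core to the other: the same change on two cores in this assay, a number 7 percentage points higher (within the scatter) from compound 2 to compound 1 and a number 23.9 percentage points higher (beyond the scatter) from compound 3 to compound 4, 16.9 percentage points apart, beyond the scatter of two such steps. Diethylamino in place of ethyl gives a number 44.5 percentage points lower from compound 1 to compound 4 (beyond the scatter), lowering the number on both cores but by different amounts: the same change on two cores in this assay, a number 61.4 percentage points lower (beyond the scatter) from compound 2 to compound 3 and a number 44.5 percentage points lower (beyond the scatter) from compound 1 to compound 4, 16.9 percentage points apart, beyond the scatter of two such steps. Both comparisons rest on the same four compounds, so they form a single observation of the two changes acting together, and they do not show why the sizes differ or whether this would hold on other cores.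

As far as these compounds go, it remains open how chloro or methoxy in place of fluoro would behave. The same applies to dimethylamino or morpholine in place of diethylamino.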